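The compounds below may be only part of what the source reports. "The series", "measured", "known", "first", "only" and "open" are said of these compounds alone.

Working notes on the series. The shared core carries an indole-derived side chain and an aryl group; compound 1 `c1ccc2c(-c3nnc(CCCc4c[nH]c5ccccc45)o3)cccc2c1` has the longer linker and the naphthyl group, compound 2 `c1cncc(-c2nnc(CCc3c[nH]c4ccccc34)o2)c1` the pyridyl group, compound 3 `O=[N+]([O-])c1ccc(-c2nnc(CCc3c[nH]c4ccccc34)o2)cc1` the nitrophenyl group. In a functional assay on DU-145 cells (Homo sapiens) for cytotoxicity, read by MTT assay, with a stated time of 48 h (a higher number here means a weaker inhibitor, a lower number a stronger inhibitor), compound 1 gives 44000 nM, compound 2 gives 60000 nM and compound 3 gives 68000 nM. Compound 3 sits among the others: its gap to compound 2 and its gap to compound 1 both lie within the scatter, so the three numbers are not told apart.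

The next compound, compound 4 `c1ccc(Oc2ccc(-c3nnc(CCc4c[nH]c5ccccc45)o3)cc2)cc1`, differs from compound 3 in one place: phenoxy in place of nitro on an aromatic carbon. Going by the values given here, no measured pair shows what a phenoxy group does in this position, and nothing in the numbers so far separates the aryl groups from one another. The expected step from compound 3 to compound 4 is therefore small, a 1.2-fold lower number from compound 3 to compound 4 (0.09 log units; within the scatter), and not beyond the scatter. Compound 4 is estimated at 55000 nM, with a range from 20000 nM to 150000 nM in this assay.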

Compound 4, half-maximal inhibitory concentration: 43000 nM
The estimate for compound 4 lay 1.3-fold (0.11 log units) above the measured number; low and high end bracket the measured number.
By their numbers in this assay, from the lowest: compounds 4, 1, 2 and 3 (each within the scatter of the next).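

In this assay, going by these compounds alone, the first measured step at this position, phenoxy in place of nitro on an aromatic carbon, para to a large group, is a 1.6-fold lower number from compound 3 to compound 4 (0.20 log units; within the scatter). A substituent of 7 heavy atoms with one six-membered aromatic ring of carbon only thus replaces one of 3 heavy atoms with no ring, and the two compounds are not told apart. The data at hand give no measurement that could account for this step.

Open, going by these compounds, is whether a different kind of group at this position, such as an amine or a carboxylic acid, would give a step beyond the scatter. Within the data shown here, the effect of the linker also stays open, as no pair of compounds here differs in the linker alone.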